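This account rests on a few compounds, and the source may have more. Where it says the series, first, only, none or still open, it means among the compounds named here.

Compound 1 `COc1cc2c(Oc3ccc(NC(=O)Nc4ccc(C(F)(F)F)cc4Cl)cc3)ccnc2cc1OCCCCCCC(=O)NO`: 970 nM
Compound 2 `COc1cc2c(Oc3ccc(NC(=O)NC4CCCCC4)cc3)ccnc2cc1OCCCCCCC(=O)NO`: 850 nM
Compound 3 `COc1ccccc1NC(=O)Nc1ccc(Oc2ccnc3cc(OCCCCCCC(=O)NO)c(OC)cc23)cc1`: not yet measured

In a functional assay on A549 cells (Homo sapiens) for antiproliferative activity, read by MTT assay (on this read-out lower numbers stand for stronger inhibition and higher numbers for weaker inhibition), compound 2 gives 850 nM and sits within the scatter of compound 1, so neither number leads. Compound 3 differs from compound 2 by 2-methoxyphenyl in place of cyclohexyl on an amide-type nitrogen in one place: 2-methoxyphenyl in place of cyclohexyl on an amide-type nitrogen. Among the compounds with values here, the only measured step at this place is a 1.1-fold lower number from compound 1 to compound 2 (0.06 log units; within the scatter) and it also exchanged an aromatic ring and cyclohexyl. One small step is thin evidence, but the expected step is a 1.1-fold higher number from compound 2 to compound 3 (0.02 log units; within the scatter) with no change beyond the scatter. For compound 3 the estimated value is 900 nM within a range of 400 nM to 2000 nM in this read-out.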

Compound 3, half-maximal inhibitory concentration: 16200 nM
The estimate for compound 3 lay 18-fold (1.26 log units) below the measured number; the whole stated range lies below it.
By their numbers in this assay, from the lowest: compounds 2 and 1 (each within the scatter of the next); then compound 3.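

The group on this amide-type nitrogen clearly matters: 2-methoxyphenyl gives a 19-fold higher number from compound 2 to compound 3 (1.28 log units; beyond the scatter) and a 17-fold higher number from compound 1 to compound 3 (1.22 log units; beyond the scatter) in this assay and so weakens inhibition sharply, though the cyclohexyl and 2-chloro-4-(trifluoromethyl)phenyl groups had given no sign of such sensitivity. Compound 1 also carries an aromatic ring here, so the presence of an aromatic ring alone does not separate compound 3 from the others. Nothing available explains this loss of activity. From the compounds shown here alone, whether an unsubstituted phenyl group would behave like compound 2 or like compound 3 remains open, so the role of the methoxy group itself is unresolved.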